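The source may report more compounds than this note shows. Statements on the series, on what has been measured and on what is new or still open speak of the compounds shown alone.

Compound 1 `CCCCNc1oc2c(C)ncc(CO)c2c1Nc1ccccn1` is one of two compounds examined in a functional assay on HEK293 cells for agonist activity at Toll-like receptor 8 (Homo sapiens), read by reporter gene assay (on this read-out lower numbers stand for an effect already at smaller amounts and higher numbers for an effect only at larger amounts of compound), where compound 1 gives 9380 nM. That is the higher of the two numbers: compound 2 `CCCCCNc1oc2c(C)ncc(CO)c2c1Nc1cccc([N+](=O)[O-])c1` gives 850 nM in this assay, a gap beyond the usual scatter, although the two structures differ in more than one place. Compound 3 `Cc1ncc(CO)c2c(Nc3ccccn3)c(N[C@@H](C)c3ccccc3)oc12` departs from compound 1 by a single change: 1-phenylethyl in place of butyl on a nitrogen on an aromatic ring. Going by the values given here, no measured pair shows this change, so its effect is not known. A modest move toward a lower number is expected, as a step of a 2.3-fold lower number from compound 1 to compound 3 (0.37 log units; beyond the scatter). Compound 3 is estimated at 4000 nM, within a range from 800 nM to 20000 nM.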

Compound 3, half-maximal effective concentration: 4270 nM
Estimate against measurement, compound 3: 1.1-fold (0.03 log units) below, and the stated range covers the measured number.
By their numbers in this assay, from the lowest: compound 2; then compound 3; then compound 1.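

This nitrogen on an aromatic ring tolerates 1-phenylethyl, which brings a six-membered aromatic ring and a defined stereocentre, in place of butyl: in this assay the change gives a 2.2-fold lower number from compound 1 to compound 3 (0.34 log units; beyond the scatter). The effect is therefore kept, and the number moves modestly lower. Nothing at hand explains this step. Going by these compounds, whether benzyl, the opposite stereocentre of 1-phenylethyl, or a longer chain such as hexyl would take the number lower still remains open. So does whether the same change would give a similar step with the other groups of compound 2 in place.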